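Benzyloxy in Place of Fluorophenyl on the Sulfonyl Ring

A few compounds are considered here, and "the series" means these few. Any claim that something is new, unique, unknown or untested is made for them only; others in the source may bear on it.

Compound 1 `COc1cc(C)ccc1S(=O)(=O)N1CCC(N2CCC(C)CC2)CC1` gives in a functional assay on DLD-1 cells (Homo sapiens) for antiproliferative activity, read by CellTiter-Glo, with a stated time of 72 h (on this read-out lower numbers stand for stronger inhibition and higher numbers for weaker inhibition), a result of > 5000 nM, which is a limit of the assay and not a number.
Compound 2 `CC1CCN(C2CCN(S(=O)(=O)c3ccc(-c4ccccc4F)cc3)CC2)CC1` gives in this assay 5 nM.
Compound 3 `Cc1cc(C)c(S(=O)(=O)N2CCC(N3CCC(Cc4ccc(F)cc4)CC3)CC2)c(C)c1` gives in this assay 18 nM.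

Among the two numbers shown, compound 2 has the lowest; compound 3 sits higher by a gap beyond the scatter. Compound 4 `CC1CCN(C2CCN(S(=O)(=O)c3ccc(OCc4ccccc4)cc3)CC2)CC1` differs from compound 2 in one place: benzyloxy in place of 2-fluorophenyl on an aromatic carbon. Going by the values given here, no measured pair shows this change, so its size rests on no direct precedent. In this assay a modest weakening is expected, and the step expected from compound 2 to compound 4 is a 4.0-fold higher number from compound 2 to compound 4 (0.60 log units; beyond the scatter). Compound 4 is therefore estimated at 20 nM, with a range from 5 nM to 80 nM.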

Compound 4, half-maximal inhibitory concentration: 385 nM
The estimate for compound 4 lay 19-fold (1.28 log units) below the measured number, outside the stated range (above it).
By their numbers in this assay, from the lowest: compound 2; then compound 3; then compound 4. At a limit, above all of these: compound 1.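

The change of 2-fluorophenyl to benzyloxy on this aromatic carbon, para to a large group, is a large one in this assay: a 77-fold higher number from compound 2 to compound 4 (1.89 log units; beyond the scatter). Both groups carry one six-membered aromatic ring of carbon only, so an aromatic ring at this carbon does not by itself keep the low number of compound 2. Nothing at hand accounts for the size of this step.

The compounds shown leave open whether the fluorine or the oxygen link matters more. Plain phenyl, phenoxy or benzyl at this carbon would separate the two.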